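A few compounds are considered here, and "the series" means these few. Any claim that something is new, unique, unknown or untested is made for them only; others in the source may bear on it.

Measured so far in an ADME assay on CCRF-CEM cells (Homo sapiens) for cytotoxicity, with a stated time of 5 days; on this read-out higher numbers stand for weaker inhibition and lower numbers for stronger inhibition:
- Compound 1 `[N-]=[N+]=N[C@H]1C[C@H](n2cnc3c(NC4CC4)nc(Cl)nc32)O[C@@H]1CO`: > 100000 nM (a limit)
- Compound 2 `[N-]=[N+]=N[C@H]1C[C@H](n2cnc3c(NC4CC4)nc(N)nc32)O[C@@H]1CO`: > 100000 nM (a limit)

Compound 1 has no exact position, since its entry of > 100000 nM is a limit of this assay and not a number. The same is true of compound 2, whose entry of > 100000 nM is also a limit. The whole picture so far is the limit of > 100000 nM in this assay, at which 2 of the 2 values shown sit.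

The next compound is compound 3 `[N-]=[N+]=N[C@H]1C[C@H](n2cnc3c(N)nc(Cl)nc32)O[C@@H]1CO`. It keeps the chloro group of compound 1 but changes the cyclopropylamino group to amino, with hydrogen in place of cyclopropyl on a nitrogen on an aromatic ring.

Within the data shown here, the only measured step is a step that the two limits leave unreadable from compound 1 to compound 2, and it swaps amino for chloro, which is a different change. Among the measured compounds shown here, it offers no size to carry over, and no measured step removes the cyclopropyl group. The expectation is therefore only a modest move towards stronger inhibition, or none beyond the scatter.

The expected step is an at least 1.2-fold lower number from compound 1 to compound 3 (0.09 log units; that floor lies within the scatter).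

Compound 3 is estimated at 80000 nM, with an expected range from 20000 nM to 100000 nM.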

Compound 3, half-maximal inhibitory concentration: > 100000 nM
Compound 3 ended at the assay's limit; the forecaster's own chance of this, stated with the estimate: 60%; middle value at least 1.2-fold (0.09 log units) from the limit.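

Compound 1 and compound 3 both stand at a limit of this assay and not at a number, and the change from cyclopropylamino to amino gives no step that can be read: the limit of > 100000 nM in this assay, at which 3 of the 3 values shown sit.

The compounds shown leave open whether changing the cyclopropylamino or chloro group makes any difference to inhibition in these cells.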